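A few compounds are considered here, and "the series" means these few. Any claim that something is new, unique, unknown or untested is made for them only; others in the source may bear on it.

Compound 1 `S=C(Nc1ccccc1)N1N=C(c2ccccc2)CC1c1ccc2c(c1)OCCO2` gives 1850 nM in a functional assay on A-375 cells (Homo sapiens) for antiproliferative activity, read by MTT assay, with a stated time of 48 h; a lower number here means a stronger inhibitor of growth, a higher number a weaker inhibitor of growth.
Compound 2 `Cc1ccc(C2=NN(C(=S)Nc3ccccc3)C(c3ccc4c(c3)OCCO4)C2)cc1` gives 6320 nM in this assay.
Compound 3 `COc1cccc(C2=NN(C(=S)Nc3ccccc3)C(c3ccc4c(c3)OCCO4)C2)c1` gives 520 nM in this assay.

Compound 3 stands lowest of the three; compound 1 is nearest and compound 2 furthest. Compound 4 `S=C(Nc1ccccc1)N1N=C(c2ccc(Cl)c(Cl)c2)CC1c1ccc2c(c1)OCCO2` is not yet measured. The change from compound 3 to compound 4 is 3,4-dichlorophenyl in place of 3-methoxyphenyl on a carbon with a double bond to nitrogen. Going by the values given here, none of the measured steps involves a chlorine, so the bearing of the earlier steps is indirect: they show that the substituent on the aromatic ring at this carbon shifts the numbers modestly, a 3.6-fold lower number from compound 1 to compound 3 (0.55 log units; beyond the scatter) and a 3.4-fold higher number from compound 1 to compound 2 (0.53 log units; beyond the scatter), and in the whole set a 12-fold lower number from compound 2 to compound 3 (1.08 log units; beyond the scatter). Because the methoxy of compound 3 sits at the favourable end of that span, 520 nM, its removal is expected to move the number upward, toward the values of compound 1 and compound 2, though the dichlorophenyl itself is unprecedented here and could fall anywhere within or slightly beyond that span. Compound 4 is therefore expected to give 1500 nM in this assay, within 400 nM to 6000 nM, a step of a 2.9-fold higher number from compound 3 to compound 4 (0.46 log units; beyond the scatter).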

Compound 4, concentration for 50% growth inhibition: 41900 nM
The estimate for compound 4 lay 28-fold (1.45 log units) below the measured number; measured number outside the range, above it.
By their numbers in this assay, from the lowest: compound 3; then compound 1; then compound 2; then compound 4.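

Going by these compounds alone, changing the aromatic group at this carbon can cost far more than the earlier compounds showed: 3,4-dichlorophenyl gives an 81-fold higher number from compound 3 to compound 4 (1.91 log units; beyond the scatter) against 3-methoxyphenyl, a 23-fold higher number from compound 1 to compound 4 (1.36 log units; beyond the scatter) against phenyl and a 6.6-fold higher number from compound 2 to compound 4 (0.82 log units; beyond the scatter) against 4-methylphenyl. Compound 4 is thus the weakest inhibitor of growth of the four in this assay, and its step from 3-methoxyphenyl is wider than any step among compound 1, compound 2 and compound 3. Nothing measured here accounts for the size of this change.

The two chlorines enter together, so the compounds shown leave open whether a phenyl ring carrying a single chlorine would raise the number as far. They also leave open how this position would respond to a phenyl ring bearing an amine or a carboxylic acid.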